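Cytotoxicity notes on a nitro-to-hydroxy exchange

The source may hold more compounds than are shown below. What is called first, only, known or untested is meant among the compounds shown, and "the series" means these compounds.

compound 1, `Cn1nnnc1SCC(=O)N/N=C/c1ccccc1[N+](=O)[O-]`, 2020000 nM
compound 2, `Cn1nnnc1SCC(=O)N/N=C/c1cccc([N+](=O)[O-])c1`, 2000000 nM

In an ADME assay on NIH3T3 cells (Mus musculus) for cytotoxicity, read by XTT assay, with a stated time of 24 h (on this read-out lower numbers stand for stronger inhibition and higher numbers for weaker inhibition), compound 1 gives 2020000 nM, the higher of the two numbers. Compound 2 gives 2000000 nM, and the two values lie within the scatter of each other, so no order between them can be read. Compound 3, `Cn1nnnc1SCC(=O)N/N=C/c1ccccc1O`, carries hydroxy in place of nitro on an aromatic carbon. Among the compounds with values here, no measured pair shows this change, so the size of the step is unknown from the data. Both measured compounds sit at the same weak level. The expected step is a 1.0-fold lower number from compound 1 to compound 3 (0.00 log units; within the scatter), none beyond the scatter. Compound 3 is expected to give 2000000 nM, with a range of 700000 nM to 5000000 nM.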

Compound 3, half-maximal inhibitory concentration: > 10000000 nM
Compound 3: only a limit was reported; the forecaster's own chance of this, stated with the estimate: 30%; middle value at least 5.0-fold (0.69 log units) from the limit.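

In this assay, hydroxy in place of nitro on this aromatic carbon, ortho to a large group, gives an at least 4.9-fold higher number from compound 1 to compound 3 (0.69 log units; beyond the scatter). Compound 1 and compound 2, both nitro compounds, lie within the scatter of each other, whereas this exchange moves the read-out beyond the scatter. The result for compound 3 is a limit and not a number, so the step has only a lower bound: the limit of > 10000000 nM in this assay, at which 1 of the 3 values shown sits.

As far as these compounds go, how far compound 3 lies past its limit remains open. Also open, from the compounds shown here alone, is whether an amine or a methoxy group on the same aromatic carbon would read like hydroxy or like nitro.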